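Swapping a difluorophenyl for a chloro-nitrophenyl carbonyl group

This account rests on a few compounds, and the source may have more. Where it says the series, first, only, none or still open, it means among the compounds named here.

Compound 3 `O=C1c2ccccc2C(=O)N1CCOC(=S)N(C(=O)c1ccc(F)cc1F)c1ccc(Cl)cc1` gives 52000 nM in an ADME assay on MT4 cells (Homo sapiens) for cytotoxicity, read by MTT assay (on this read-out higher numbers stand for lower toxicity in this test and lower numbers for higher toxicity in this test), and stands as the lowest of the two numbers shown. Compound 2 `Cc1ccc(N(C(=O)c2cccc([N+](=O)[O-])c2)C(=S)OCCN2C(=O)c3ccccc3C2=O)cc1` gives 100000 nM in this assay, a gap from compound 3 that stays within the scatter. Compound 1 `Cc1ccc(N(C(=O)c2cccc(C)c2)C(=S)OCCN2C(=O)c3ccccc3C2=O)cc1` reaches only a limit of this assay, > 100000 nM. Compound 4 `O=C1c2ccccc2C(=O)N1CCOC(=S)N(C(=O)c1ccc(Cl)c([N+](=O)[O-])c1)c1ccc(Cl)cc1` is not yet measured; it differs from compound 3 by 4-chloro-3-nitrophenyl in place of 2,4-difluorophenyl on a carbonyl carbon. Among the compounds with values here, the one measured step that also brings in a nitro group, a number no higher from compound 1 to compound 2 (the limit leaves the size open), rests on the limit of > 100000 nM in this assay, at which 1 of the 3 values shown sits, and so its size cannot be read. With no readable step to lean on, the step of a 1.0-fold lower number from compound 3 to compound 4 (0.02 log units; within the scatter) is expected to stay within the scatter. Compound 4 is therefore estimated at 50000 nM, between 20000 nM and 120000 nM.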

Compound 4, half-maximal cytotoxic concentration: 48000 nM
Compound 4: middle estimate off by 1.0-fold (0.02 log units), on the high side; the range from low to high includes it.
By their numbers in this assay, from the lowest: compounds 4, 3 and 2 (each within the scatter of the next, the first and the last beyond it).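

Within the data shown here, on a carbonyl carbon whose other neighbour is an amide-type nitrogen, 4-chloro-3-nitrophenyl in place of 2,4-difluorophenyl gives the first readable step at this position (a 1.1-fold lower number from compound 3 to compound 4 (0.03 log units; within the scatter)) in this assay and leaves the read-out within the scatter. A nitro-bearing aryl group can therefore be compared here with a measured partner, which the earlier step could not offer, and that earlier step cannot be read: the limit of > 100000 nM in this assay, at which 1 of the 4 values shown sits. Going by these compounds, whether an amine or a carboxylic acid on this aryl group would move the number stays open.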